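A few compounds are considered here, and "the series" means these few. Any claim that something is new, unique, unknown or untested is made for them only; others in the source may bear on it.

Measured so far in a functional assay on HeLa cells (Homo sapiens) for cytotoxicity, read by MTT assay, with a stated time of 24 h; on this read-out higher numbers stand for weaker inhibition and lower numbers for stronger inhibition:
- compound 1 `C=CC1=C(C(=O)Nc2ccccc2)C(c2ccc(Cl)c(Cl)c2)OC1`: > 100000 nM
- compound 2 `C=CC1=C(C(=O)NCCCCC)C(c2ccc(Cl)c(Cl)c2)OC1`: > 100000 nM

Both of these values are limits of the assay rather than numbers. For compound 1 the value in this assay is a limit. For compound 2 the value in this assay is likewise a limit, so compound 2 stands at the edge of what this assay can report, with no exact figure. Within the data shown here, the single measured step, a step that the two limits leave unreadable from compound 1 to compound 2, therefore cannot be read in size, since (the limit of > 100000 nM in this assay, at which 2 of the 2 values shown sit).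

Compound 3 `C=CC1=C(C(=O)O)C(c2ccc(Cl)c(Cl)c2)OC1` differs from compound 2 by the change (hydroxy in place of pentylamino on a carbonyl carbon). Among the measured compounds shown here, no measured step bears on a change of this kind, because the only step available, a step that the two limits leave unreadable from compound 1 to compound 2, is itself unreadable. The expectation for compound 3 can rest only on the fact that compound 2 shows a limit in this assay, and so compound 3 is expected to remain at or near that limit as well. For compound 3 the estimate in this assay is 150000 nM, with a range from 50000 nM to 500000 nM. The step this estimate implies is expected to be a step that the limit leaves unreadable from compound 2 to compound 3, that is, no change beyond the scatter.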

Compound 3, half-maximal inhibitory concentration: 10300 nM
The estimate for compound 3 lay 15-fold (1.16 log units) above the measured number, and the stated range ends above it.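

In this assay, the carbonyl carbon whose other neighbour is a double-bonded ring carbon turns out to be a place where a change can be read: hydroxy in place of pentylamino gives an at least 9.7-fold lower number from compound 2 to compound 3 (0.98 log units; beyond the scatter), and hydroxy in place of anilino gives an at least 9.7-fold lower number from compound 1 to compound 3 (0.98 log units; beyond the scatter). Among these compounds, two quite different groups on the amide nitrogen, one a chain and the other a ring, thus give way to the same hydroxy with the same readable result, and compound 3 is the only one of the three compounds with an exact number rather than a limit. The comparison between the two amides themselves still cannot be read, and the carboxylic acid of compound 3 can be set against them only from one side, because both amides sit at a limit of the assay: the limit of > 100000 nM in this assay, at which 2 of the 3 values shown sit.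

The compounds shown leave open whether the free hydroxy is needed at this carbonyl carbon or whether a methyl ester or an unsubstituted amide would give a similar number. They also leave open whether an amine in place of the carbonyl group would keep this effect.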